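Trading a Phenol for a Nitrile on the Pendant Ring

The source may hold more compounds than are shown below. What is called first, only, known or untested is meant among the compounds shown, and "the series" means these compounds.

Measured so far:
compound 1, `CC(=O)N1N=C(c2cc(O)c(O)c([N+](=O)[O-])c2)CC1c1cccs1`, 210 nM
compound 2, `CC(=O)N1N=C(c2cc(O)c(O)c([N+](=O)[O-])c2)CC1c1cccc(O)c1`, 75 nM

In an assay for inhibition of Catechol O-methyltransferase (Rattus norvegicus), read by fluorescence and spectrophotometry (a higher number here means a weaker inhibitor, a lower number a stronger inhibitor), compound 2 holds the lowest of the two numbers; the step of a 2.8-fold lower number from compound 1 to compound 2 (0.45 log units; beyond the scatter) moved beyond the usual scatter. Compound 3, `CC(=O)N1N=C(c2cc(O)c(O)c([N+](=O)[O-])c2)CC1c1cccc(C#N)c1`, differs from compound 2 by cyano in place of hydroxy on an aromatic carbon. For the measured compounds named here, the single measured step replaced the whole pendant ring, so it bears on this change only loosely, and no measured step tells what the hydroxy itself contributes. Going by the values given here, compound 3 is therefore expected to land between the two known numbers, at 130 nM with a range of 55 nM to 320 nM, an expected step of a 1.7-fold higher number from compound 2 to compound 3 (0.24 log units; within the scatter).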

Compound 3, half-maximal inhibitory concentration: 79 nM
Compound 3: middle estimate off by 1.6-fold (0.22 log units), on the high side, within the range that was stated.
By their numbers in this assay, from the lowest: compounds 2 and 3 (each within the scatter of the next); then compound 1.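

In this assay, cyano in place of hydroxy gives a 1.1-fold higher number from compound 2 to compound 3 (0.02 log units; within the scatter), so at this position the hydroxy can be exchanged for a group with no hydrogen-bond donor without a step beyond the scatter. The 3-cyanophenyl group also stands apart from thiophen-2-yl, with a 2.7-fold lower number from compound 1 to compound 3 (0.42 log units; beyond the scatter), as the 3-hydroxyphenyl group did. Nothing available explains why hydroxy and cyano read alike here.

On these data alone, whether the plain phenyl ring alone would read like these two substituted rings remains open. So does the effect of an amine or a carboxylic acid on this aromatic carbon.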